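Swapping benzofuran for iodo at the assay limit

The source may report more compounds than this note shows. Statements on the series, on what has been measured and on what is new or still open speak of the compounds shown alone.

In a functional assay on HCT-116 cells (Homo sapiens), read by MTT assay, with a stated time of 72 h (on this read-out higher numbers stand for weaker inhibition and lower numbers for stronger inhibition), compound 3 (`Cc1ncnc2c1c(-c1cc3ccccc3o1)cn2[C@@H]1O[C@H](CO)[C@@H](O)[C@H]1O`) gives > 20000 nM, which is a limit and not a number. Compound 2 (`CN(C)c1ncnc2c1c(-c1cc3ccccc3o1)cn2[C@@H]1O[C@H](CO)[C@@H](O)[C@H]1O`) gives > 20000 nM, also a limit. Within the data shown here, compound 1 (`COc1ncnc2c1c(-c1cc3ccccc3o1)cn2[C@@H]1O[C@H](CO)[C@@H](O)[C@H]1O`) reads 14500 nM, the only true number so far.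

The next compound, compound 4 (`Cc1ncnc2c1c(I)cn2[C@@H]1O[C@H](CO)[C@@H](O)[C@H]1O`), is changed at a different place: iodo in place of 1-benzofuran-2-yl on an aromatic carbon.

Among the measured compounds shown here, all the measured steps keep the 1-benzofuran-2-yl and alter another group. They are an at least 1.3-fold higher number from compound 1 to compound 2 (0.13 log units; that floor lies within the scatter) and an at least 1.3-fold higher number from compound 1 to compound 3 (0.13 log units; that floor lies within the scatter), while the third is a step that the two limits leave unreadable from compound 2 to compound 3. None of them sizes the new swap, so they give only weak guidance.

Because of the limit of > 20000 nM in this assay, at which 2 of the 3 values shown sit, only a move towards lower numbers could be read in this assay. The expected change is an at least 4.0-fold lower number from compound 3 to compound 4 (0.60 log units; beyond the scatter), a rough expectation in that direction. For compound 4 the estimated value is 5000 nM, with an expected range of 300 nM to 20000 nM.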

Compound 4, half-maximal inhibitory concentration: 7570 nM
Estimate against measurement, compound 4: 1.5-fold (0.18 log units) below, within the range that was stated.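

Changing the group at this position, two ring bonds from the ring nitrogen, has a readable effect in this assay: iodo in place of 1-benzofuran-2-yl gives an at least 2.6-fold lower number from compound 3 to compound 4 (0.42 log units; beyond the scatter). Among these compounds, the earlier steps all kept the 1-benzofuran-2-yl, so this is the first sign that, with the methyl group held fixed, the two-ring group is not required for a measurable value on these cells, and that a single iodine atom there gives one. The true size of the step stays unknown and only its floor can be given, because the starting point of compound 3 is a limit: the limit of > 20000 nM in this assay, at which 2 of the 4 values shown sit.

As far as these compounds go, it remains open whether iodo would give a similar step with the methoxy or dimethylamino group of the other compounds in place of methyl. From the compounds shown here alone, it is also open how bromo or phenyl at this same position would compare with iodo.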